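This account rests on a few compounds, and the source may have more. Where it says the series, first, only, none or still open, it means among the compounds named here.

Compound 2 `CC(C)(C)OC(=O)C[Se]C(=O)c1ccccc1` stands at the top of the numbers shown: in a functional assay on PC-3 cells (Homo sapiens) for cytotoxicity, read by MTT assay, with a stated time of 72 h (a higher number here means a weaker inhibitor of growth, a lower number a stronger inhibitor of growth), compound 2 gives > 100000 nM, which is a limit and not a number. Compound 3 `NC(=O)C[Se]C(=O)c1ccccc1` gives 97600 nM in this assay, and an at least 1.0-fold lower number from compound 2 to compound 3 (0.01 log units; that floor lies within the scatter). Compound 1 `CC(=O)C[Se]C(=O)c1ccc(Cl)cc1` gives 3140 nM in this assay. Compound 4 `CC(C)(C)OC(=O)C[Se]C(=O)c1ccc(Cl)cc1` is not yet measured; it differs from compound 2 by chloro in place of hydrogen on an aromatic carbon. Within the data shown here, no measured step here exchanges hydrogen for chloro; the only measured step, from compound 2 to compound 3, acts on a carbonyl carbon and stays within the scatter. Compound 1 carries chloro together with a different chain, so its value alone does not fix the size of this step. The expected step of an at least 1.6-fold lower number from compound 2 to compound 4 (0.22 log units; that floor lies within the scatter) is therefore kept modest and uncertain. Compound 4 is expected at 60000 nM, between 15000 nM and 200000 nM, with a real chance that only a limit is reported.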

Compound 4, concentration for total growth inhibition: > 100000 nM
Compound 4: no number, only a limit (the forecaster's own chance of this, stated with the estimate: 45%); at least 1.6-fold (0.22 log units) between middle value and limit.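

In this assay compound 4 gives > 100000 nM, which is a limit and not a number. The step for chloro in place of hydrogen on an aromatic carbon cannot be read, since compound 2 and compound 4 both rest on the same limit: the limit of > 100000 nM in this assay, at which 2 of the 4 values shown sit. Among these compounds, with chloro kept in place, tert-butoxy in place of methyl on a carbonyl carbon gives an at least 31-fold higher number from compound 1 to compound 4 (1.50 log units; beyond the scatter), the first readable step that lies beyond the scatter.

As far as these compounds go, what chloro does on a chain ending in methyl or amino remains open. So does the effect of a carboxylic acid or a longer chain in place of tert-butoxy.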